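Nitro to amino: expected gain in cell cytotoxicity

The source may report more compounds than this note shows. Statements on the series, on what has been measured and on what is new or still open speak of the compounds shown alone.

Measured so far in a functional assay on B16 cells (Mus musculus) for cytotoxicity, read by MTT assay, with a stated time of 3 days; a higher number here means a weaker inhibitor, a lower number a stronger inhibitor:
- compound 1, `COc1cccc(/C=C/C(=O)c2ccc(OC)c([N+](=O)[O-])c2)c1`, gives > 100000 nM, which is a limit of the assay rather than a number
- compound 2, `COc1cccc(/C=C/C(=O)c2ccc(OC)c(N)c2)c1`, gives 33000 nM
- compound 3, `COc1ccc(OC)c(/C=C/C(=O)c2ccc(OC)c([N+](=O)[O-])c2)c1`, gives 13000 nM

Among the two numbers available, compound 3 stands lowest, with compound 2 the next higher. Compound 4, `COc1ccc(OC)c(/C=C/C(=O)c2ccc(OC)c(N)c2)c1`, differs from compound 3 by one change: amino in place of nitro on an aromatic carbon. The same exchange has been seen once, an at least 3.0-fold lower number from compound 1 to compound 2 (0.48 log units; beyond the scatter), and because compound 1 sits at the limit of > 100000 nM in this assay, at which 1 of the 3 values shown sits, that step is known only as a lower bound. The other measured step, an at least 7.6-fold lower number from compound 1 to compound 3 (0.88 log units; beyond the scatter), concerns a different change and does not bear on this one. A lower number, a stronger inhibitor, is therefore expected, with the step estimated as a 3.3-fold lower number from compound 3 to compound 4 (0.51 log units; beyond the scatter). Compound 4 is expected to give 4000 nM in this assay, most likely between 1000 nM and 15000 nM.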

Compound 4, half-maximal inhibitory concentration: 5600 nM
Compound 4: middle estimate off by 1.4-fold (0.15 log units), on the low side, within the range that was stated.
By their numbers in this assay, from the lowest: compound 4; then compound 3; then compound 2. At a limit, above all of these: compound 1.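

In this assay amino in place of nitro now gives a step with a full size (a 2.3-fold lower number from compound 3 to compound 4 (0.37 log units; beyond the scatter)) rather than only a bound. The direction therefore holds on both cores, with the size comparison unsettled: the same change on two cores in this assay, an at least 3.0-fold lower number (0.48 log units; beyond the scatter) from compound 1 to compound 2 and a 2.3-fold lower number (0.37 log units; beyond the scatter) from compound 3 to compound 4; the limit leaves it open whether they differ. Methoxy in place of hydrogen also lowers the number when amino is present (a 5.9-fold lower number from compound 2 to compound 4 (0.77 log units; beyond the scatter)).

From the compounds shown here alone, whether another group at this aromatic carbon, such as hydroxyl or dimethylamino, would lower the number further remains open. So does whether the amino group needs the methoxy group printed ortho to it.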